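A ring swap on a weakly cytotoxic compound

The source may report more compounds than this note shows. Statements on the series, on what has been measured and on what is new or still open speak of the compounds shown alone.

Compound 1 `Cc1ccc(S(=O)(=O)c2nc3ccccc3nc2N2CCc3ccccc3C2)cc1` gives 39000 nM
Compound 2 `O=S(=O)(c1ccc(Br)cc1)c1nc2ccccc2nc1N1CCc2ccccc2C1` gives > 50000 nM (a limit)

Going by the values given here, in a functional assay on HCT-116 cells (Homo sapiens) for cytotoxicity, read by MTT assay, with a stated time of 72 h (a higher number here means a weaker inhibitor, a lower number a stronger inhibitor), compound 1 gives 39000 nM as the only actual number so far. Compound 2 shows > 50000 nM as a limit of the assay, not a number. Compound 3 `Cc1ccc(S(=O)(=O)c2nc3ccccc3nc2N2CCCC(O)C2)cc1` puts 3-hydroxypiperidin-1-yl in place of 1,2,3,4-tetrahydroisoquinolin-2-yl on an aromatic carbon on an aromatic carbon. Among the compounds with values here, the one measured step of an at least 1.2-fold higher number from compound 1 to compound 2 (0.10 log units; that floor lies within the scatter) concerns another group, bromo in place of methyl, and gives little guidance on this swap. The estimated step of a 1.0-fold higher number from compound 1 to compound 3 (0.01 log units; within the scatter) means that no change beyond the scatter is expected in this assay here. Compound 3 is estimated at 40000 nM with an expected range from 15000 nM to 100000 nM in this assay.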

Compound 3, half-maximal inhibitory concentration: 3270 nM
The estimate for compound 3 lay 12-fold (1.09 log units) above the measured number; the whole stated range lies above it.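

Swapping the group at this position on the shared core produces the first clear shift among the compounds shown: in this assay, 3-hydroxypiperidin-1-yl in place of 1,2,3,4-tetrahydroisoquinolin-2-yl gives a 12-fold lower number from compound 1 to compound 3 (1.08 log units; beyond the scatter). The earlier bromo for methyl step concerned another place and said nothing about this one. The compounds shown offer no measurement that explains the gain.

The swap removes an aromatic ring and adds a hydroxyl group at once, so their shares remain unseparated. Plain piperidin-1-yl or morpholin-4-yl at this position would help to tell them apart.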